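The source may hold more compounds than are shown below. What is called first, only, known or untested is meant among the compounds shown, and "the series" means these compounds.

Measured so far in a functional assay on MDA-MB-231 cells (Homo sapiens) for cytotoxicity, read by MTT assay; on this read-out lower numbers stand for stronger inhibition and higher numbers for weaker inhibition:
- compound 1 `COc1cc(-c2cn(-c3ccc(Oc4ccccc4)cc3)nn2)ccc1O`: "not determined" (no result reported)
- compound 2 `Nc1ccc(-c2cn(-c3ccc(OC(F)(F)F)cc3)nn2)cc1`: > 10 nM
- compound 3 `Oc1cc(O)cc(-c2cn(-c3ccc(Oc4ccccc4)cc3)nn2)c1`: > 10000 nM

Compound 1 gives no number in this assay. For compound 2 the result is a limit of the assay, (the limit of > 10 nM in this assay, at which 1 of the 3 values shown sits). Going by the values given here, for compound 3 the result is likewise a limit and not a number, (the limit of > 10000 nM in this assay, at which 1 of the 3 values shown sits); compound 3 therefore stands at the weak end of what has been recorded, and no measured step connects it to any other compound of the set.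

The unmeasured compound 4 `Nc1ccc(-c2cn(-c3ccc(Oc4ccccc4)cc3)nn2)cc1` differs from compound 3 in one place: 4-aminophenyl in place of 3,5-dihydroxyphenyl on an aromatic carbon. The rest of the molecule, including the phenoxy-bearing aryl on the ring nitrogen, is kept.

With compound 3 known only as a limit, the step to compound 4 cannot be anchored to a measured difference. Compound 2, which carries the same 4-aminophenyl group on a different core partner, is itself only a limit, so it fixes no number either. The expectation is that compound 4 falls in the direction of stronger inhibition than compound 3, by an amount that is uncertain. Compound 4 is estimated at 5000 nM, with a range from 500 nM to 50000 nM, which as an expected step means an at least 2.0-fold lower number from compound 3 to compound 4 (0.30 log units; that floor lies within the scatter).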

Compound 4, half-maximal inhibitory concentration: > 10000 nM
Compound 4: a limit, no number (the forecaster's own chance of this, stated with the estimate: 50%); middle value at least 2.0-fold (0.30 log units) from the limit.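

In this assay compound 4 gives > 10000 nM, a limit and not a number. Compound 2 and compound 3 are also known only as limits, so neither step to compound 4 can be read. The compounds shown leave open whether 4-aminophenyl in place of 3,5-dihydroxyphenyl changes the read-out at all.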